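One Methyl Off the Amine Nitrogen of Compound 3

The source may hold more compounds than are shown below. What is called first, only, known or untested is meant among the compounds shown, and "the series" means these compounds.

Of the compounds shown here, three built on a shared core have been tested in a functional assay on Bel-7402 cells (Homo sapiens) for antiproliferative activity, read by MTT assay, with a stated time of 72 h; on this read-out lower numbers stand for stronger inhibition and higher numbers for weaker inhibition. Compound 1 `COc1ccc(Cn2c(C(=O)O)c(CNCc3cccc(O)c3)c3ccccc32)cc1` reads > 50000 nM, which is a limit of the assay and not a number. Compound 2 `COc1cccc(CNCc2c(C(=O)O)n(Cc3ccccc3F)c3ccccc23)c1` reads > 50000 nM, which is also a limit. For the measured compounds named here, compound 3 `COc1ccc(Cn2c(C(=O)O)c(CN(C)Cc3cccc(OC)c3)c3ccc(C)cc32)cc1` gives 33000 nM, the only true number so far. The other two readings stand at the limit of > 50000 nM in this assay, at which 2 of the 3 values shown sit.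

Compound 4 `COc1ccc(Cn2c(C(=O)O)c(CNCc3cccc(OC)c3)c3ccc(C)cc32)cc1` has not yet been measured. It differs from compound 3 in one place: hydrogen in place of methyl on an amine nitrogen. Going by the values given here, no measured pair isolates this change, so the data give no direct size for it. Compound 1 and compound 2 also carry hydrogen on that nitrogen, but each differs from compound 4 elsewhere as well.

The expectation rests mainly on compound 3 at 33000 nM, a value already not far from the limit of > 50000 nM in this assay, at which 2 of the 3 values shown sit. In this assay no change beyond the scatter is expected, and the estimated step reads a 1.2-fold higher number from compound 3 to compound 4 (0.08 log units; within the scatter). A result reported only as a limit would also fit this expectation. For compound 4 the expected value is 40000 nM, with an estimated range from 20000 nM to 75000 nM.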

Compound 4, half-maximal inhibitory concentration: 9830 nM
For compound 4 the middle estimate is 4.1-fold (0.61 log units) above the measured one, outside the stated range (below it).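

For the compounds shown here, the change of methyl to hydrogen on the amine nitrogen gives, in this assay, a 3.4-fold lower number from compound 3 to compound 4 (0.53 log units; beyond the scatter), so this position has a step of measured size on the read-out, which no earlier pair could provide. Hydrogen on that nitrogen therefore does not by itself hold a compound at the ceiling of the assay, since compound 4 carries it and still gives a true number. That reading adds a second true number to the set, and it lies clear of the ceiling: the limit of > 50000 nM in this assay, at which 2 of the 4 values shown sit.

Going by these compounds, what remains open is how far this step reaches, as it rests on a single pair that carries the (3-methoxybenzyl)amino group on one shared core. The compounds shown say nothing about an ethyl group or a longer chain on that nitrogen, or about an acetyl group that would turn the amine into an amide, so it cannot be told whether hydrogen is the best of the possible groups here or merely better than methyl.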